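Swapping an ether oxygen for a carbonyl bridge

The source may hold more compounds than are shown below. What is called first, only, known or untested is meant among the compounds shown, and "the series" means these compounds.

Three compounds share a core and were tested in a functional assay on NCI-H460 cells (Homo sapiens) for cytotoxicity, read by MTT assay, with a stated time of 72 h; on this read-out lower numbers stand for stronger inhibition and higher numbers for weaker inhibition. Compound 1, `CC(C)c1[nH]cnc1/C=c1\[nH]c(=O)/c(=C/c2cccc(Oc3ccc(F)cc3)c2)[nH]c1=O`, gives 8.8 nM. Compound 2, `CC(C)c1[nH]cnc1/C=c1\[nH]c(=O)/c(=C/c2cccc(C(=O)c3ccc(F)cc3)c2)[nH]c1=O`, differs from compound 1 in one place, ((4-fluorophenyl)carbonyl in place of 4-fluorophenoxy on an aromatic carbon). Compound 2 gives 3.2 nM; that change made a 2.8-fold lower number from compound 1 to compound 2 (0.44 log units; beyond the scatter). Compound 3, `COCc1ccc(/C=c2\[nH]c(=O)/c(=C/c3cccc(Oc4ccc(F)cc4)c3)[nH]c2=O)o1`, carries a different group on the double-bonded chain carbon, (5-(methoxymethyl)furan-2-yl in place of 5-isopropyl-1H-imidazol-4-yl on a double-bonded chain carbon bound to an aromatic carbon), and gives 14 nM; from compound 1 to compound 3 the step was a 1.6-fold higher number from compound 1 to compound 3 (0.20 log units; within the scatter), so these two values cannot be told apart.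

Compound 4, `COCc1ccc(/C=c2\[nH]c(=O)/c(=C/c3cccc(C(=O)c4ccc(F)cc4)c3)[nH]c2=O)o1`, has not yet been measured. For the measured compounds named here, it differs from compound 3 by (4-fluorophenyl)carbonyl in place of 4-fluorophenoxy on an aromatic carbon, which is the same change as the one from compound 1 to compound 2, at the same place. Among the compounds here that change occurs twice, once measured and once to be measured. Going by the values given here, the measured case is the only guide: compound 2 stands against compound 1 as a 2.8-fold lower number from compound 1 to compound 2 (0.44 log units; beyond the scatter). Because a 1.6-fold higher number from compound 1 to compound 3 (0.20 log units; within the scatter) lies within the scatter, the carbonyl-for-ether swap is expected to act about as it did before. The step from compound 3 to compound 4 is therefore estimated as a 2.8-fold lower number from compound 3 to compound 4 (0.45 log units; beyond the scatter). Compound 4 is expected to give 5 nM in this assay, most likely between 2.5 nM and 10 nM.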

Compound 4, half-maximal inhibitory concentration: 2.9 nM
Beside the measured number, compound 4's estimate is 1.7-fold (0.24 log units) above it, within the range that was stated.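

In this assay, putting (4-fluorophenyl)carbonyl in place of 4-fluorophenoxy again lowers the number on a second core, with a 4.8-fold lower number from compound 3 to compound 4 (0.68 log units; beyond the scatter), and the size of this step agrees with that of the earlier one: the same change on two cores in this assay, a 2.8-fold lower number (0.44 log units; beyond the scatter) from compound 1 to compound 2 and a 4.8-fold lower number (0.68 log units; beyond the scatter) from compound 3 to compound 4, 1.8-fold (0.24 log units) apart, within the scatter of two such steps. The other change, 5-(methoxymethyl)furan-2-yl in place of 5-isopropyl-1H-imidazol-4-yl, gives a 1.1-fold lower number from compound 2 to compound 4 (0.04 log units; within the scatter), so it makes no measurable difference with the carbonyl in place, just as it made none with the ether: the same change on two cores in this assay, a 1.6-fold higher number (0.20 log units; within the scatter) from compound 1 to compound 3 and a 1.1-fold lower number (0.04 log units; within the scatter) from compound 2 to compound 4, 1.8-fold (0.24 log units) apart, within the scatter of two such steps. Within these four compounds, the two changes therefore behave as if independent of each other, but the apparently larger second carbonyl step cannot be read as a real gain, and two cores cannot show that the swap would carry over to any other core or explain why it lowers the number.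

The compounds shown leave open whether other links between the two aromatic rings, such as a methylene or an amine, would serve as well as the carbonyl. They also leave open what would follow if the fluorine gave way to a chlorine or a nitrile, or if the methoxymethyl group gave way to a carboxylic acid.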